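Replacing the Thiomorpholinyl Carbonyl Group of Compound 2

This account rests on a few compounds, and the source may have more. Where it says the series, first, only, none or still open, it means among the compounds named here.

In an in vivo functional assay on the whole organism for inhibition, with Rattus norvegicus as the target (on this read-out higher numbers stand for an effect only at larger amounts of compound and lower numbers for an effect already at smaller amounts), compound 1 `CCCCc1nc(C)c(CC(=O)N2CCCC2)c(=O)n1Cc1ccc(-c2ccccc2-c2nnn[nH]2)cc1` gives 0.056 mg/kg and compound 2 `CCCCc1nc(C)c(CC(=O)N2CCSCC2)c(=O)n1Cc1ccc(-c2ccccc2-c2nnn[nH]2)cc1` gives 0.038 mg/kg. Among the compounds with values here, these two values lie within the scatter of each other, so compound 2 stands level with the only other measured compound. Compound 3 `CCCCc1nc(C)c(CCC(=O)N2CCC[C@H]2C(=O)OC)c(=O)n1Cc1ccc(-c2ccccc2-c2nnn[nH]2)cc1` has not yet been measured. It carries ((2-(methoxycarbonyl)pyrrolidin-1-yl)carbonyl)methyl in place of (thiomorpholin-4-yl)carbonyl on a saturated chain carbon bound to an aromatic carbon.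

Within the data shown here, only one measured step bears on this change, and only partly. It placed thiomorpholin-4-yl where pyrrolidin-1-yl had been on a carbonyl carbon and gave a 1.5-fold lower number from compound 1 to compound 2 (0.17 log units; within the scatter). Among the measured compounds shown here, no measured compound carries the entering group, so the data give no direct size for this change. The small size of that one step argues against expecting a very large move in this assay, yet the larger change leaves room for more than scatter. A moderate shift towards a higher number is expected, with low confidence. The estimate amounts to an expected 2.6-fold higher number from compound 2 to compound 3 (0.42 log units; beyond the scatter). For compound 3 the estimated value is 0.1 mg/kg, with an expected range from 0.03 mg/kg to 0.35 mg/kg.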

Compound 3, dose for half-maximal effect: 0.063 mg/kg
The estimate for compound 3 lay 1.6-fold (0.20 log units) above the measured number; the range from low to high includes it.
By their numbers in this assay, from the lowest: compounds 2, 1 and 3 (each within the scatter of the next).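

Within the data shown here, the position on a saturated chain carbon bound to an aromatic carbon proves more accommodating in this assay than the single ring swap between compound 1 and compound 2 could show. The much larger ((2-(methoxycarbonyl)pyrrolidin-1-yl)carbonyl)methyl group, with its added ester and defined stereocentre, leaves the read-out within the scatter on both comparisons: a 1.7-fold higher number from compound 2 to compound 3 (0.22 log units; within the scatter) and a 1.1-fold higher number from compound 1 to compound 3 (0.05 log units; within the scatter). Compound 3 therefore stands level with both earlier compounds, and no measurement at hand explains this tolerance.

Compound 3 changes the chain length, the ester and the stereocentre together, so the compounds shown cannot separate any contribution of the extra chain carbon from that of the methoxycarbonyl group. As far as these compounds go, it also remains open whether the level read-out would hold with a carboxylic acid in place of the methyl ester, with the opposite configuration at the stereocentre, or with a simple pyrrolidin-1-yl amide on the same longer chain.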